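From a chlorohydrin side chain to a prenyl group

This account rests on a few compounds, and the source may have more. Where it says the series, first, only, none or still open, it means among the compounds named here.

Compound 1 `C=CC(C)(C)c1[nH]c2ccc(C[C@@H](Cl)C(C)(C)O)cc2c1/C=C1\NC(=O)[C@H](C)NC1=O` and compound 2 `C=CC(C)(C)c1[nH]c2c(C[C@@H](O)C(C)(C)Cl)cccc2c1/C=C1\NC(=O)[C@H](C)NC1=O` share one core and differ only in their side chains. In a functional assay on HL-60 cells (Homo sapiens) for cytotoxicity, read by MTT assay, with a stated time of 72 h (on this read-out lower numbers stand for stronger inhibition and higher numbers for weaker inhibition), compound 1 reaches only the assay limit, > 50000 nM. Compound 2 likewise gives only the limit > 50000 nM in this assay. Within the data shown here, what the numbers show is the limit of > 50000 nM in this assay, at which 2 of the 2 values shown sit, so no step between measured compounds can be read. Compound 3 `C=CC(C)(C)c1[nH]c2c(CC=C(C)C)cccc2c1/C=C1\NC(=O)[C@H](C)NC1=O` arises from compound 2 through the change (2-methylprop-1-en-1-yl in place of 2-chloro-1-hydroxy-2-methylpropyl on a saturated chain carbon bound to an aromatic carbon). Among the measured compounds shown here, with no measured step to guide it, a step no larger than the scatter is expected, an at least 1.1-fold lower number from compound 2 to compound 3 (0.04 log units; that floor lies within the scatter). Compound 3 is therefore estimated at 45000 nM, ranging from 15000 nM to 150000 nM.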

Compound 3, half-maximal inhibitory concentration: > 50000 nM
Compound 3 gave a limit, no number; the forecaster's own chance of this, stated with the estimate: 65%; middle value at least 1.1-fold (0.04 log units) away from the limit.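

No step can be read from compound 2 to compound 3: compound 3 also gives only the limit > 50000 nM in this assay and no number. The compounds shown leave open whether these side chains differ at all in cytotoxicity, because the values stop at one limit: the limit of > 50000 nM in this assay, at which 3 of the 3 values shown sit.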